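Ester chain length and cytotoxicity on rabbit kidney cells

The compounds below may be only part of what the source reports. "The series", "measured", "known", "first", "only" and "open" are said of these compounds alone.

compound 1 `CCCCCCCCOC(=O)C(O)Cn1cnc2c(N)ncnc21` in a functional assay on PRK cells (Oryctolagus cuniculus) for cytotoxicity (on this read-out lower numbers stand for higher toxicity in this test and higher numbers for lower toxicity in this test), gives 100 ug/mL
compound 2 `COCCOC(=O)C(O)Cn1cnc2c(N)ncnc21` gives a limit of the assay, not a number, namely > 400 ug/mL
compound 3 `CC(C)CCOC(=O)C(O)Cn1cnc2c(N)ncnc21` gives 400 ug/mL

Compound 3 holds the highest of the two numbers; its nearest neighbour is compound 1, with a 4.0-fold higher number from compound 1 to compound 3 (0.60 log units; beyond the scatter). Compound 4 `CCOC(=O)C(O)Cn1cnc2c(N)ncnc21` differs from compound 3 by hydrogen in place of isopropyl on a saturated chain carbon, two bonds along the chain from an oxygen next to a carbonyl group. Two measured steps cut the same chain: a 4.0-fold higher number from compound 1 to compound 3 (0.60 log units; beyond the scatter) and an at least 4.0-fold higher number from compound 1 to compound 2 (0.60 log units; beyond the scatter), both moving the number upward. The step of a number no higher from compound 2 to compound 3 (the limit leaves the size open) has no readable size, see (the limit of > 400 ug/mL in this assay, at which 1 of the 3 values shown sits). A further cut is therefore expected to give a number no lower than that of compound 3. Compound 4 is expected near 400 ug/mL, within 200 ug/mL to 800 ug/mL, a step of no change at the digits printed from compound 3 to compound 4 (within the scatter), with a fair chance that only a limit is reported.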

Compound 4, minimum cytotoxic concentration: > 400 ug/mL
Compound 4 gave a limit, no number; the forecaster's own chance of this, stated with the estimate: 55%; the middle value sits exactly at the limit.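

In this assay compound 4 gives > 400 ug/mL as a limit of the assay, not a number. Cutting the chain from isopentyl to ethyl gives a number no lower from compound 3 to compound 4 (the limit leaves the size open). Among the compounds shown here, the only new step of readable size is an at least 4.0-fold higher number from compound 1 to compound 4 (0.60 log units; beyond the scatter), while the step to compound 4 from compound 2 cannot be read. Short esters at this position now cluster at the top of the range, so no order among them can be drawn: the limit of > 400 ug/mL in this assay, at which 2 of the 4 values shown sit.

Any real difference among compound 2, compound 3 and compound 4 stays hidden behind that limit. Also open, on these data alone, is how an amine or a carboxylic acid at the chain end, or a chain longer than that of compound 1, would read in this assay against these values.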